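Compound 1 to compound 3: hydroxy to methoxy

The source may report more compounds than this note shows. Statements on the series, on what has been measured and on what is new or still open speak of the compounds shown alone.

Among the measured compounds shown here, in a functional assay on RPMI-8226 cells (Homo sapiens) for antiproliferative activity, read by sulforhodamine B assay, with a stated time of 48 h (on this read-out higher numbers stand for weaker inhibition of growth and lower numbers for stronger inhibition of growth), compound 1 (`O=C(NCCCNc1cc(-c2cn(-c3ccccc3)nc2-c2cccc(O)c2)ccn1)Nc1ccc(F)cc1`) gives 5470 nM and compound 2 (`O=C(NCCCNc1cc(-c2cn(-c3ccccc3)nc2-c2cccc(O)c2)ccn1)Nc1cccc(C(F)(F)F)c1`) gives 6120 nM as its value, so compound 1 stands level with its only measured neighbour. Compound 3 (`COc1cccc(-c2nn(-c3ccccc3)cc2-c2ccnc(NCCCNC(=O)Nc3ccc(F)cc3)c2)c1`) differs from compound 1 by methyl in place of hydrogen on an oxygen on an aromatic ring (3-hydroxyphenyl to 3-methoxyphenyl). For the measured compounds named here, the one measured step, a 1.1-fold higher number from compound 1 to compound 2 (0.05 log units; within the scatter), lies at another place, and no measured step touches the hydroxy group, so it offers only weak guidance. In this assay the expected step is a 1.2-fold higher number from compound 1 to compound 3 (0.07 log units; within the scatter) and no shift beyond the scatter is expected. Compound 3 is estimated at 6500 nM with an expected range from 3000 nM to 14000 nM for this value.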

Compound 3, concentration for total growth inhibition: 24600 nM
Compound 3: middle estimate off by 3.8-fold (0.58 log units), on the low side; measured number outside the range, above it.
By their numbers in this assay, from the lowest: compounds 1 and 2 (each within the scatter of the next); then compound 3.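

In this assay, among the compounds shown here, capping the hydroxy group as methoxy gives a 4.5-fold higher number from compound 1 to compound 3 (0.65 log units; beyond the scatter) and so weakens growth inhibition, the first step in this short series to pass the scatter. For the compounds shown here, the 3-hydroxyphenyl position is therefore sensitive to this change, whereas the only earlier step lay at another place and stayed within the scatter.

Going by these compounds, whether an amino group or a carboxylic acid in place of the hydroxy group would keep the value of compound 1 remains open. Also open, on these data alone, is whether a longer chain on the oxygen, such as ethoxy, would move the value further than methoxy. No measurement at hand explains the step.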